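The source may report more compounds than this note shows. Statements on the series, on what has been measured and on what is new or still open speak of the compounds shown alone.

Compound 1 `O=C(Nc1cc(Sc2ncn[nH]2)c(O)c2ccccc12)c1ccc(Cl)cc1` is one of three compounds examined in a functional assay on MDA-MB-231 cells (Homo sapiens) for antiproliferative activity, read by MTT assay, with a stated time of 48 h (a lower number here means a stronger inhibitor, a higher number a weaker inhibitor), where compound 1 gives 25700 nM. Within this set compound 1 stands second highest of the three numbers. Its nearest neighbour is compound 2 `O=C(Nc1cc(Sc2ncnc3nc[nH]c23)c(O)c2ccccc12)c1ccc(Cl)cc1`, which in this assay gives 23000 nM; the step of a 1.1-fold lower number from compound 1 to compound 2 (0.05 log units; within the scatter) lies within the scatter, so these two read as equivalent. The furthest is compound 3 `COc1ccc(/C=C/C(=O)Nc2cc(Sc3ncn[nH]3)c(O)c3ccccc23)cc1OC`, which in this assay gives 52500 nM, a number beyond the scatter above that of compound 1.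

Compound 4 `O=C(/C=C/c1ccc(Cl)cc1)Nc1cc(Sc2ncn[nH]2)c(O)c2ccccc12` has not yet been measured. It differs from compound 1 in one place: 2-(4-chlorophenyl)ethenyl in place of 4-chlorophenyl on a carbonyl carbon. For the measured compounds named here, no measured step bears directly on this change. Going by the values given here, the only measured step, from compound 1 to compound 2, concerns the group on the sulfur and was within the scatter, so it says nothing about the carbonyl side. Compound 3 carries an ethenyl-linked aryl amide of a different kind and shows the highest number of the three, but it differs from compound 1 in more than one place, so only its value is informative. On this basis compound 4 is expected to sit near compound 1, with the step of a 1.4-fold higher number from compound 1 to compound 4 (0.13 log units; within the scatter) estimated to be small and, if anything, towards a higher number. The estimate for compound 4 is 35000 nM, with a range from 15000 nM to 80000 nM.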

Compound 4, half-maximal inhibitory concentration: > 100000 nM
Compound 4: a limit, no number; the forecaster's own chance of this, stated with the estimate: 10%; middle value at least 2.8-fold (0.45 log units) away from the limit.
By their numbers in this assay, from the lowest: compounds 2 and 1 (each within the scatter of the next); then compound 3. At a limit, above all of these: compound 4.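

In this assay the value of compound 4 is a limit of the assay and not a number: the limit of > 100000 nM in this assay, at which 1 of the 4 values shown sits.

For the compounds shown here, replacing 4-chlorophenyl with 2-(4-chlorophenyl)ethenyl on the carbonyl carbon gives an at least 3.8-fold higher number from compound 1 to compound 4 (0.59 log units; beyond the scatter), the first single-place step in this set to lie beyond the scatter, so the group on this carbonyl carbon matters in a way the group on the sulfur did not, where the change gave a 1.1-fold lower number from compound 1 to compound 2 (0.05 log units; within the scatter). With the double-bonded chain kept, exchanging the aryl group gives an at least 1.9-fold higher number from compound 3 to compound 4 (0.27 log units; that floor lies within the scatter), and that floor lies within the scatter, so the pair does not settle whether 4-chlorophenyl and 3,4-dimethoxyphenyl differ on this chain.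

The compounds shown leave open whether the double bond itself or the longer link goes with the step, a question that a saturated chain on the carbonyl carbon would address. They also leave open how an amine or a carboxylic acid on the aryl ring of the ethenyl series would read in this assay.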